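Notes on phosphate-bearing nucleoside esters: compound 4

This account rests on a few compounds, and the source may have more. Where it says the series, first, only, none or still open, it means among the compounds named here.

Measured so far in a functional assay on U-118-MG cells (Homo sapiens) for cytotoxicity, read by MTT assay, with a stated time of 48 h; on this read-out lower numbers stand for stronger inhibition and higher numbers for weaker inhibition:
compound 1, `O=C(O[C@H]1C[C@H](n2cc(F)c(=O)[nH]c2=O)O[C@@H]1COP(=O)(O)Oc1ccccc1)c1ccccc1`, 970 nM
compound 2, `O=C(O[C@H]1C[C@H](n2cc(F)c(=O)[nH]c2=O)O[C@@H]1COP(=O)(O)Oc1cccnc1)c1ccccc1`, 920 nM
compound 3, `O=c1[nH]c(=O)n([C@H]2C[C@H](O)[C@@H](COP(=O)(O)Oc3ccccc3)O2)cc1F`, 14600 nM

Compound 3 gives the highest number of the three in this assay, and its separation from both others lies beyond the scatter. That height comes in a single step: a 15-fold higher number from compound 1 to compound 3 (1.18 log units; beyond the scatter). Compound 1 and compound 2 sit within the scatter of each other.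

Compound 4, `O=c1[nH]c(=O)n([C@H]2C[C@H](O)[C@@H](COP(=O)(O)Oc3cccnc3)O2)cc1F`, is yet to be measured. It differs from compound 3 in one place: pyridin-3-yl in place of phenyl on an oxygen. Within the data shown here, the one measured step that bears on this change is the same swap made on the benzoyl-bearing pair, a 1.1-fold lower number from compound 1 to compound 2 (0.02 log units; within the scatter), which stays within the scatter. Among the measured compounds shown here, nothing among the measured compounds indicates that the swap reads differently when hydrogen rather than benzoyl sits on the oxygen on the saturated carbon, although only that single pair speaks to it. The expected step is therefore none beyond the scatter, a 1.1-fold lower number from compound 3 to compound 4 (0.03 log units; within the scatter). For compound 4 the estimate in this assay is 13500 nM, with a range from 7000 nM to 28000 nM.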

Compound 4, half-maximal inhibitory concentration: 27500 nM
Estimate against measurement, compound 4: 2.0-fold (0.31 log units) below; low and high end bracket the measured number.
By their numbers in this assay, from the lowest: compounds 2 and 1 (each within the scatter of the next); then compounds 3 and 4 (each within the scatter of the next).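

With pyridin-3-yl in place of phenyl on an oxygen now read on a second core, this assay gives a 1.9-fold higher number from compound 3 to compound 4 (0.27 log units; within the scatter), so on neither core does this swap move the number beyond the scatter: the same change on two cores in this assay, a 1.1-fold lower number (0.02 log units; within the scatter) from compound 1 to compound 2 and a 1.9-fold higher number (0.27 log units; within the scatter) from compound 3 to compound 4, 2.0-fold (0.30 log units) apart, within the scatter of two such steps

Hydrogen in place of benzoyl on an oxygen on a saturated carbon now has a second reading as well, a 30-fold higher number from compound 2 to compound 4 (1.48 log units; beyond the scatter), so the large rise in the number no longer rests on the phenyl pair alone: the same change on two cores in this assay, a 15-fold higher number (1.18 log units; beyond the scatter) from compound 1 to compound 3 and a 30-fold higher number (1.48 log units; beyond the scatter) from compound 2 to compound 4, 2.0-fold (0.30 log units) apart, within the scatter of two such steps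

Across these four compounds, the benzoyl change separates the numbers and the change on the oxygen bound to phosphorus does not.

Still open, going by these compounds, is whether acetyl or a longer acyl chain in place of benzoyl would keep numbers close to those of compound 1 and compound 2. Also open, on these data alone, is whether an amine or a carboxylic acid on the phenyl ring would read as quietly as pyridin-3-yl does.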